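Naphthalen-1-yl Replaces 2-Chlorophenyl in a Melanocortin Series

This account rests on a few compounds, and the source may have more. Where it says the series, first, only, none or still open, it means among the compounds named here.

Measured so far in an assay for binding affinity to Melanocortin receptor 4 (Homo sapiens); on this read-out lower numbers stand for stronger inhibition and higher numbers for weaker inhibition:
Compound 1 `CCN(CC)CCCC(C)/N=C(/N)NC(=O)c1cccc(F)c1CCc1ccc2ccccc2c1` gives 690 nM.
Compound 2 `CCN(CC)CCCC(C)/N=C(/N)NC(=O)c1cccc(F)c1CCc1ccccc1Cl` gives 26000 nM.

Going by the values given here, compound 2 stands at the higher of the two numbers; the only measured step, a 38-fold higher number from compound 1 to compound 2 (1.58 log units; beyond the scatter), was large. Compound 3 `CCN(CC)CCCC(C)/N=C(/N)NC(=O)c1cccc(F)c1CCc1cccc2ccccc12` differs from compound 2 by naphthalen-1-yl in place of 2-chlorophenyl on a saturated chain carbon, two bonds along the chain from an aromatic carbon. This reverses the kind of change that produced the earlier step, though with naphthalen-1-yl rather than the naphthalen-2-yl of compound 1, so a large downward step in this assay is expected, perhaps not quite the full size of the earlier one. Compound 3 is therefore expected to give 1500 nM, between 300 nM and 8000 nM, a step of a 17-fold lower number from compound 2 to compound 3 (1.24 log units; beyond the scatter).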

Compound 3, inhibition constant: 89 nM
Estimate against measurement, compound 3: 17-fold (1.23 log units) above; the measured number lies below the stated range.
By their numbers in this assay, from the lowest: compound 3; then compound 1; then compound 2.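

In this assay, this place on the saturated chain carbon responds not only to the group but to how that group is attached: naphthalen-1-yl in place of naphthalen-2-yl gives a 7.8-fold lower number from compound 1 to compound 3 (0.89 log units; beyond the scatter) and leaves compound 3 with the lowest number of the three. Against 2-chlorophenyl, the same group gives a 290-fold lower number from compound 2 to compound 3 (2.47 log units; beyond the scatter) and so outdoes the earlier naphthalen-2-yl gain. Nothing at hand explains either step. Going by these compounds, how a 4-chlorophenyl or a phenyl on a longer chain would compare stays open, as does whether the preference for naphthalen-1-yl holds on any other core.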